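The source may hold more compounds than are shown below. What is called first, only, known or untested is meant among the compounds shown, and "the series" means these compounds.

In a functional assay on NFS-60 cells (Mus musculus) for inhibition, with a stated time of 72 h (on this read-out higher numbers stand for weaker inhibition of growth and lower numbers for stronger inhibition of growth), compound 1 `Nc1ncnc2c(C(=O)Nc3cccc4c3c(Br)nn4Cc3ccccc3)csc12` gives 1010 nM, compound 2 `Cc1cccc(Cn2nc(Br)c3c(NC(=O)c4csc5c(N)ncnc45)cccc32)n1` gives 27.5 nM and compound 3 `Nc1ncnc2c(C(=O)Nc3cccc4c3c(Br)nn4CC3CCCCC3)csc12` gives 254 nM, the second highest of the three numbers. Compound 4 `CCn1nc(Cn2nc(Br)c3c(NC(=O)c4csc5c(N)ncnc45)cccc32)cc1C(C)C` has not yet been measured. It differs from compound 3 in one group: 1-ethyl-5-isopropyl-1H-pyrazol-3-yl in place of cyclohexyl on a saturated chain carbon bound to an aromatic nitrogen. Three measured steps changed the group at this same place: a 4.0-fold lower number from compound 1 to compound 3 (0.60 log units; beyond the scatter), a 37-fold lower number from compound 1 to compound 2 (1.56 log units; beyond the scatter) and a 9.2-fold higher number from compound 2 to compound 3 (0.97 log units; beyond the scatter). Going by the values given here, compound 2 is the only measured compound with an aromatic ring containing nitrogen here, and the entering group also has one, so its 27.5 nM is the closest guide. Among the compounds with values here, no measured compound carries a five-membered aromatic ring here, so the expectation stays loose. A modest move to a lower number is expected in this assay, and the estimated change is a 3.6-fold lower number from compound 3 to compound 4 (0.56 log units; beyond the scatter). For compound 4 the estimated value is 70 nM, with an expected range from 15 nM to 300 nM.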

Compound 4, concentration for 50% growth inhibition: 62 nM
For compound 4 the middle estimate is 1.1-fold (0.05 log units) above the measured one, within the range that was stated.
By their numbers in this assay, from the lowest: compound 2; then compound 4; then compound 3; then compound 1.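

In this assay a five-membered aromatic ring with 2 hetero atoms works at this place, since 1-ethyl-5-isopropyl-1H-pyrazol-3-yl gives a 4.1-fold lower number from compound 3 to compound 4 (0.61 log units; beyond the scatter) and a 16-fold lower number from compound 1 to compound 4 (1.21 log units; beyond the scatter). Nitrogen-containing aromatic rings now give the two lowest numbers among these four compounds, with no exception, yet this one still trails 6-methylpyridin-2-yl, with a 2.3-fold higher number from compound 2 to compound 4 (0.35 log units; beyond the scatter). No measurement here explains these steps. Open, from the compounds shown here alone, is what the ethyl and isopropyl groups each contribute, and how a pyrazole without them, or a carboxylic acid or an amine at this place, would read.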